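Swapping a fluoro for a hydroxylated group on a shared core

A few compounds are considered here, and "the series" means these few. Any claim that something is new, unique, unknown or untested is made for them only; others in the source may bear on it.

Measured compounds:
compound 1, `CC1CN(CCn2ccc3ccc(Br)cc32)CCN1`, gives 52%
compound 2, `Brc1cccc2ccn(CCN3CCN4CCCCC4C3)c12`, gives 13%
compound 3, `CN1CCCN(CCn2ccc3ccc(F)cc32)CC1`, gives 60%

All three values come from an assay on HEK293 cells for binding affinity to 5-hydroxytryptamine receptor 7 (Homo sapiens), read by radioligand binding, tested at 1 uM; a lower number here means less inhibition, a higher number more inhibition at the concentration tested (going by the name of the read-out). Among the three numbers, compound 3 stands highest. Its nearest neighbour is compound 1, whose number is lower by an amount that lies within the usual scatter of this assay, so the two cannot be told apart. Compound 2 lies furthest away, with a number well beyond the scatter below compound 3, and only for that pair is a real gap established.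

The next compound, compound 4, `CN1CCCN(CCn2ccc3ccc(C(C)(C)O)cc32)CC1`, keeps the core of compound 3 and changes a single substituent: 1-hydroxy-1-methylethyl in place of fluoro on an aromatic carbon. Within the data shown here, no pair of measured compounds differing in just one place has been measured, so there is nothing in these data that shows how this assay answers such a swap on this core.

Without such a reference, a cautious expectation is a modest step downward, of a size that may not exceed the scatter. The expected step from compound 3 to compound 4 is a number 13 percentage points lower from compound 3 to compound 4 (beyond the scatter). Compound 4 is estimated at 47%, with a range from 22% to 70%.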

Compound 4, a percentage reported as inhibition, at one concentration (the size of the read-out at that concentration, not a potency): 6%
Estimate against measurement, compound 4: 41 percentage points above; the measured number lies below the stated range.
By their numbers in this assay, from the lowest: compounds 4 and 2 (each within the scatter of the next); then compounds 1 and 3 (each within the scatter of the next).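

In this assay, the aromatic carbon that carries the fluoro in compound 3 turns out not to be a place where any substituent is accepted equally: putting 1-hydroxy-1-methylethyl there gives a number 54 percentage points lower from compound 3 to compound 4 (beyond the scatter). This is the first pair shown that differs in one place only, so it is the first direct reading of how this assay answers a change on the shared core; the earlier compounds differ from one another in several places at once and could not isolate any single swap. The entering group has more heavy atoms than fluoro and brings a hydrogen-bond donor and acceptor, but nothing measured here says which of these features, if any, lies behind the drop.

The compounds shown leave open whether the hydroxyl or the bulk of the new group matters more, a question that a 1-methylethyl group without the hydroxyl, or a smaller hydroxymethyl group, on the same aromatic carbon could help to separate. They also leave open how a chloro or a methoxy group would fare there, and whether the same swap would have a similar effect on the cores of the other compounds.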